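This account rests on a few compounds, and the source may have more. Where it says the series, first, only, none or still open, it means among the compounds named here.

Measured in a functional assay, read by spectrophotometry, tested at 100 uM; a higher number here means a weaker inhibitor, a lower number a stronger inhibitor:
- compound 1 `Cc1ccc(/C=C/C(=O)c2cccc(NC(=O)c3cc(-c4ccncc4)n[nH]3)c2)cc1`: 64600 nM
- compound 2 `O=C(/C=C/c1ccc(Cl)cc1)c1cccc(NC(=O)c2cc(-c3ccncc3)n[nH]2)c1`: 78900 nM

In this assay, compound 2 stands at 78900 nM, which is within the scatter of compound 1 at 64600 nM. The two compounds therefore cannot be ranked. Going by the values given here, the only measured comparison is a 1.2-fold higher number from compound 1 to compound 2 (0.09 log units; within the scatter).

Compound 3 `O=C(/C=C/c1cccs1)c1cccc(NC(=O)c2cc(-c3ccncc3)n[nH]2)c1` carries thiophen-2-yl in place of 4-chlorophenyl on a double-bonded chain carbon bound to a double-bonded chain carbon. This replaces the whole aromatic ring, whereas the measured step only swaps chloro for methyl on an aromatic carbon. Among the compounds with values here, no measured compound has a ring other than a six-membered one of carbon only at this place, so the evidence is indirect. Within the data shown here, the one relevant step, a 1.2-fold higher number from compound 1 to compound 2 (0.09 log units; within the scatter), gives no sign that this end of the molecule moves the number, and no direction can be drawn from it. No shift beyond the scatter is therefore expected in this assay, though the range is kept wide. The expected step is a 1.1-fold lower number from compound 2 to compound 3 (0.05 log units; within the scatter). The estimated value for compound 3 is 70000 nM, with an expected range of 30000 nM to 150000 nM.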

Compound 3, half-maximal inhibitory concentration: 70000 nM
For compound 3 middle estimate and measured number coincide at the digits printed; low and high end bracket the measured number.
By their numbers in this assay, from the lowest: compounds 1, 3 and 2 (each within the scatter of the next).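

In this assay, thiophen-2-yl in place of 4-chlorophenyl gives a 1.1-fold lower number from compound 2 to compound 3 (0.05 log units; within the scatter), and thiophen-2-yl in place of 4-methylphenyl gives a 1.1-fold higher number from compound 1 to compound 3 (0.03 log units; within the scatter). Going by these compounds alone, the earlier step changed only one group on a six-membered aromatic ring of carbon only; these steps replace the whole ring with a five-membered aromatic ring with 1 hetero atom, going from 7 heavy atoms to 5 in the step from compound 2, and neither step moves the number beyond the scatter, so at this place on a double-bonded chain carbon bound to a double-bonded chain carbon, the ring change, like the earlier chloro-for-methyl swap, gives no readable shift and compounds 1, 2 and 3 cannot be ranked. No measured property is available to account for this flat result.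

On these data alone, all three compounds carry an aromatic ring at this place, so the effect of an amine, a carboxylic acid or a saturated ring such as cyclohexyl there remains open. The rest of the core of compound 1 is the same throughout the compounds shown, so the response of the number to changes elsewhere also remains open.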